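The compounds below may be only part of what the source reports. "The series", "measured", "known", "first", "only" and "open" are said of these compounds alone.

Among the compounds with values here, in a functional assay on NCI-H522 cells (Homo sapiens) for inhibition, read by sulforhodamine B assay, with a stated time of 48 h (a lower number here means a stronger inhibitor of growth, a higher number a weaker inhibitor of growth), compound 2 `COc1ccc(C2([C@H]3C[C@H](n4cc(C)c(=O)[nH]c4=O)O[C@@H]3CO[Si](C)(C)C(C)(C)C)SCCCS2)cc1OC` gives 2690 nM, the only number available for the series, so its rank cannot be judged. In this assay, compound 1 `Cc1cn([C@H]2C[C@H](CC3=CC(=O)C(=O)C=C3)[C@@H](CO[Si](C)(C)C(C)(C)C)O2)c(=O)[nH]c1=O` is recorded as no result reported and so adds no number. Compound 3 `COc1ccc(C2([C@H]3C[C@@H](n4cc(C)c(=O)[nH]c4=O)O[C@@H]3CO[Si](C)(C)C(C)(C)C)SCCCS2)cc1OC` is the stereoisomer of compound 2: the two compounds have the same atoms and bonds and differ only in configuration as drawn: 1 of 3 stereo elements differ; a stereocentre at a saturated ring carbon is drawn R in compound 2 and S in compound 3. The same atoms and bonds are kept, and a stereocentre at a saturated ring carbon is drawn R in compound 2 and S in compound 3. Within the data shown here, no measured step shows what such an inversion does, so no shift beyond the scatter is expected in this assay, and no direction is favoured. The expected change is a 1.1-fold higher number from compound 2 to compound 3 (0.05 log units; within the scatter). Compound 3 is estimated at 3000 nM, with an expected range of 1000 nM to 9000 nM.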

Compound 3, concentration for 50% growth inhibition: 5620 nM
Estimate against measurement, compound 3: 1.9-fold (0.27 log units) below; the range from low to high includes it.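

In this assay, within the data shown here, the inversion at the saturated ring carbon, drawn R in compound 2 and S in compound 3, gives a 2.1-fold higher number from compound 2 to compound 3 (0.32 log units; beyond the scatter) and is the first readable step. The step is modest, but it shows that this stereocentre alone can move growth inhibition beyond the scatter, with the R form giving the lower number. The shift can be assigned to this one centre because nothing else changes: the fact that compounds 2 and 3 differ only in the configuration as drawn.

On these data alone, whether the inversion has the same effect when a free hydroxyl replaces the silyl ether remains open. As far as these compounds go, the effect of the other stereocentres also remains open.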